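The source may report more compounds than this note shows. Statements on the series, on what has been measured and on what is new or still open speak of the compounds shown alone.

Compound 1, `COc1ccc(-c2cc(=O)c3c(OC)cc(OC)cc3n2S(=O)(=O)c2ccc(F)cc2)cc1`, gives only a limit in a functional assay on HepG2 cells (Homo sapiens) for antiproliferative activity, with a stated time of 72 h (on this read-out lower numbers stand for an effect already at smaller amounts and higher numbers for an effect only at larger amounts of compound), namely > 65500 nM.
Compound 2, `COc1ccc(-c2cc(=O)c3c(OC)cc(OC)cc3n2S(=O)(=O)c2ccc(Cl)cc2)cc1`, gives only a limit in this assay, namely > 34400 nM.
Compound 3, `COC(=O)c1cc(=O)c2cc(NC(=O)Nc3ccc(Cl)c(Cl)c3)ccc2[nH]1`, gives only a limit in this assay, namely > 6350 nM.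

Compound 1 and compound 2 share one core and differ by fluoro in place of chloro on an aromatic carbon. Between them lies a step that the two limits leave unreadable from compound 2 to compound 1. Both values are limits, as the lines the limit of > 65500 nM in this assay, at which 1 of the 3 values shown sits, and the limit of > 34400 nM in this assay, at which 1 of the 3 values shown sits, show, so the size of that step cannot be read. Compound 3 has a different core; how the two cores differ is not broken down here. Its value is also a limit, as the limit of > 6350 nM in this assay, at which 1 of the 3 values shown sits, shows.

Compound 4, `COC(=O)c1cc(=O)c2cc(NC(=O)Nc3ccc(F)c(Cl)c3)ccc2[nH]1`, is not yet measured. It differs from compound 3 by fluoro in place of chloro on an aromatic carbon. Within the data shown here, this is the same kind of change as the one from compound 2 to compound 1, but not the same: in compound 4 the place is ortho to a chloro group as well as para to a large group, whereas in compound 1 it is only para to a large group.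

For compound 4 in this assay a step that the limit leaves unreadable from compound 3 to compound 4 is expected, and this expectation rests on compound 3 having only the limit > 6350 nM while the earlier step of the same kind stayed unreadable. Compound 4 is estimated at 12000 nM, with a range from 4000 nM to 40000 nM, and a limit rather than a number is quite likely.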

Compound 4, half-maximal effective concentration: > 6350 nM
Compound 4 gave a limit, no number; the forecaster's own chance of this, stated with the estimate: 60%; the middle value is on the limit's open side.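

Compound 3 and compound 4 both give only a limit and no number, so the step between them cannot be read, and the swap of chloro for fluoro shows no size here: the limit of > 6350 nM in this assay, at which 2 of the 4 values shown sit.
The compounds shown leave open whether fluoro in place of chloro on an aromatic carbon changes the result in this assay at all, on either core, and what number any of these four compounds would reach.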